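The source may hold more compounds than are shown below. What is called first, only, known or untested is meant among the compounds shown, and "the series" means these compounds.

Measured so far:
- compound 1 `Cc1nn(-c2ncnc3nc[nH]c23)c2c1C(OCCn1nccc1C)CC(=O)N2` — 10 nM
- compound 2 `CC(C)(C)c1cc(C(=O)N/N=C/c2ccc(O)cc2O)[nH]n1` — 240 nM
- compound 3 `O=C1/C(=C/NCCCO)C(c2ccccc2)=NN1c1nc2ccccc2s1` — 200 nM

All three numbers come from a functional assay on HEK293 cells for agonist activity at G-protein coupled receptor 39 (Homo sapiens), read by scintillation proximity assay and inositol phosphate accumulation, with a stated time of 75 min, in the presence of a further agent that is not named here; on this read-out higher numbers stand for an effect only at larger amounts of compound and lower numbers for an effect already at smaller amounts. Compound 1 stands lowest of the three. The nearest number is that of compound 3, and the gap between them lies beyond the scatter; the furthest is that of compound 2, also beyond the scatter. Compounds 2 and 3 share no core with compound 1, so no single-change step between measured compounds is available, and nothing among these three tells how the core of compound 1 responds to a change at the ether side chain.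

Compound 4 `Cc1nn(-c2ncnc3nc[nH]c23)c2c1C(OCC(C)C)CC(=O)N2` is the next compound of the series, built on the core of compound 1. The change is isopropyl in place of (5-methyl-1H-pyrazol-1-yl)methyl on a saturated chain carbon bound to an oxygen on a saturated carbon

Within the data shown here, with no measured step to lean on, the expectation rests on compound 1 alone, whose reading in this assay is 10 nM. A loss is expected, of moderate size rather than none: the step from compound 1 to compound 4 is estimated as a 6.0-fold higher number from compound 1 to compound 4 (0.78 log units; beyond the scatter), a weakening that goes beyond the scatter. Compound 4 is accordingly expected at 60 nM, with a range from 15 nM to 300 nM, the wide range reflecting the absence of any comparable step among the measured compounds.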

Compound 4, half-maximal effective concentration: 4 nM
Compound 4: middle estimate off by 15-fold (1.18 log units), on the high side; the whole stated range lies above it.
By their numbers in this assay, from the lowest: compound 4; then compound 1; then compounds 3 and 2 (each within the scatter of the next).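

In this assay, isopropyl in place of (5-methyl-1H-pyrazol-1-yl)methyl on a saturated chain carbon bound to an oxygen on a saturated carbon gives a 2.5-fold lower number from compound 1 to compound 4 (0.40 log units; beyond the scatter), the first single-change step available in the series. At this position, the five-membered aromatic ring with 2 hetero atoms and its 2 hydrogen-bond acceptors are therefore not required for a low number: the entering group, with 3 heavy atoms, no ring and 0 hydrogen-bond acceptors, reads lower than the leaving group with 7 heavy atoms. No measurement at hand accounts for the step, and since the two groups differ at once in size, ring and acceptor count, this single comparison cannot assign it to any one of those differences.

As far as these compounds go, it remains open whether the lower number goes with losing the pyrazole ring or with the branched alkyl group itself; an unbranched propyl chain, a longer chain, a cyclopropyl group, or an amine or a carboxylic acid on the ether side chain would help separate these readings. With only two side chains shown on this core, it is also open how far the trend extends in either direction.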